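Swapping the amide side chain on a shared core

The source may report more compounds than this note shows. Statements on the series, on what has been measured and on what is new or still open speak of the compounds shown alone.

For the measured compounds named here, compound 1, with structure `Nc1ccc(Nc2c(C(=O)NCc3ccc(F)cc3)nc(Br)c3cccnc23)cc1`, is the only member of this set with a reported number: in a functional assay on MCF7 cells (Homo sapiens) for cytotoxicity, read by MTT assay, with a stated time of 72 h (a higher number here means a weaker inhibitor, a lower number a stronger inhibitor), compound 1 gives 4000 nM. Compound 2, with structure `COc1cccc(CNC(=O)c2nc(Br)c3cccnc3c2N[C@H]2CC[C@H](N)CC2)c1`, shares the same core but carries a different amine on it; in this assay compound 2 gives "not determined" (no result reported), so no number stands for it. Compound 3, with structure `N[C@H]1CC[C@H](Nc2c(C(=O)NCc3cccs3)nc(Br)c3cccnc23)CC1`, keeps the amine of compound 2 and changes only the amide side chain: thiophen-2-yl in place of 3-methoxyphenyl on a saturated chain carbon bound to an amide-type nitrogen. With no measured pair of this kind in the set, the size of the step in this assay is unknown; a change of this kind is expected to stay small, in either direction or within the scatter. Compound 3 is therefore expected to come out near 3000 nM, with a range from 500 nM to 20000 nM.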

Compound 3, half-maximal inhibitory concentration: 7300 nM
Compound 3: middle estimate off by 2.4-fold (0.39 log units), on the low side; measured number inside the range.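

Compound 2 has no number to set against compound 3 in this assay, so no step can be read between them. Going by these compounds, whether 3-methoxyphenyl or thiophen-2-yl on this side chain gives the stronger effect stays open. No supporting data explain the value of compound 3.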